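Removing the Vinyl Group: Cytotoxicity of a Thiophene Amine

The source may report more compounds than this note shows. Statements on the series, on what has been measured and on what is new or still open speak of the compounds shown alone.

Measured compounds:
Compound 1 `CCc1csc(CN[C@@H]2C[C@H]3C[C@@H]([C@H]2C)C3(C)C)c1` gives 25000 nM
Compound 2 `C=Cc1csc(CN[C@@H]2C[C@H]3C[C@@H]([C@H]2C)C3(C)C)c1` gives 6250 nM

The two measured compounds share a bicyclic amine core joined to a thiophene ring, and they differ only in the group on an aromatic carbon of that ring. In an ADME assay on MDCK cells (Canis lupus familiaris) for cytotoxicity, read by microscopy, with a stated time of 48 h (on this read-out higher numbers stand for lower toxicity in this test and lower numbers for higher toxicity in this test), compound 1 gives 25000 nM, whereas compound 2 gives 6250 nM. Within the data shown here, the single step between them, a 4.0-fold lower number from compound 1 to compound 2 (0.60 log units; beyond the scatter), is the only comparison in hand, and it places compound 2 as the lower of the two numbers, that is, the more toxic of the pair in this assay.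

Compound 3 `C[C@H]1[C@H](NCc2cccs2)C[C@H]2C[C@@H]1C2(C)C` has not yet been measured. It differs from compound 2 by hydrogen in place of vinyl on an aromatic carbon. Among the measured compounds shown here, no measured step removes a group from this aromatic carbon altogether; the one step available only swaps ethyl for vinyl. That step moved the number by a modest amount, so a step of similar size is plausible here, but its direction cannot be read from the data. Compound 3 is therefore expected to lie close to compound 2, with a wide range, at 12500 nM (from 3000 nM to 50000 nM), a step of a 2.0-fold higher number from compound 2 to compound 3 (0.30 log units; within the scatter).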

Compound 3, minimum cytotoxic concentration: 25000 nM
For compound 3 the middle estimate is 2.0-fold (0.30 log units) below the measured one; the range from low to high includes it.
By their numbers in this assay, from the lowest: compound 2; then compounds 1 and 3 (each within the scatter of the next).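

Among these compounds, replacing vinyl with hydrogen on this aromatic carbon gives a 4.0-fold higher number from compound 2 to compound 3 (0.60 log units; beyond the scatter) in this assay, which is the first measured step that takes a group off this position altogether and leaves only a hydrogen atom there. Hydrogen in place of ethyl gives no change at the digits printed from compound 1 to compound 3 (within the scatter), so the unsubstituted ring and the ethyl-bearing ring cannot be told apart on this read-out, and of the three compounds only compound 2, the one with vinyl, stands apart, with steps to both others printed as beyond the scatter. Nothing at hand explains why vinyl alone stands apart here.

Still open, as far as these compounds go, is whether other groups on this aromatic carbon, such as a methyl, an ethynyl, a bromine atom or a methoxy group, would sit with hydrogen and ethyl or with vinyl on this read-out. The compounds shown also leave open whether vinyl would give a similar step at another carbon of the five-membered aromatic ring, or on a different amine such as a simple cyclohexylamine in place of the shared core.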